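Swapping methylsulfanyl for a benzyl-selenium group

A few compounds are considered here, and "the series" means these few. Any claim that something is new, unique, unknown or untested is made for them only; others in the source may bear on it.

Of the compounds shown here, two sharing one core have been measured in a functional assay on HT-29 cells (Homo sapiens) for cytotoxicity, read by MTT assay, with a stated time of 72 h; a higher number here means a weaker inhibitor of growth, a lower number a stronger inhibitor of growth. Compound 1 `C[Se]/C(=N\C(=O)c1cc2ccccc2s1)NC(=O)c1cc2ccccc2s1` gives 5620 nM. Among the compounds with values here, compound 2 `CS/C(=N\C(=O)c1cc2ccccc2s1)NC(=O)c1cc2ccccc2s1` gives 16800 nM, the highest of the two numbers, so the weaker growth inhibitor; the one step in the set, a 3.0-fold higher number from compound 1 to compound 2 (0.48 log units; beyond the scatter), shows that replacing selenium by sulfur raised the number by a modest amount.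

Compound 3 `O=C(/N=C(/NC(=O)c1cc2ccccc2s1)[Se]Cc1ccccc1)c1cc2ccccc2s1` has not yet been measured. The change from compound 2 is a group of 8 heavy atoms (7 carbon, 1 selenium; one six-membered aromatic ring of carbon only) in place of a group of 2 heavy atoms (1 carbon, 1 sulfur; no ring), on a carbon with a double bond to nitrogen. Within the data shown here, the only step that bears on it is the selenium-to-sulfur swap, which went the opposite way; the replacement of methyl by benzyl has no precedent here. Reversing that step, the number for compound 3 is expected to fall in this assay by about a 3.7-fold lower number from compound 2 to compound 3 (0.57 log units; beyond the scatter). The estimate for compound 3 is 4500 nM, with a range from 1500 nM to 13000 nM.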

Compound 3, concentration for 50% growth inhibition: 6510 nM
The estimate for compound 3 lay 1.4-fold (0.16 log units) below the measured number, and the stated range covers the measured number.
By their numbers in this assay, from the lowest: compounds 1 and 3 (each within the scatter of the next); then compound 2.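

In this assay, phenyl can stand on the saturated chain carbon bound to selenium without a readable effect: the step is a 1.2-fold higher number from compound 1 to compound 3 (0.06 log units; within the scatter), so the two selenium compounds cannot be told apart here. The wider replacement of methylsulfanyl gives a 2.6-fold lower number from compound 2 to compound 3 (0.41 log units; beyond the scatter), which means that both selenium compounds, with or without the phenyl, give lower numbers than the sulfur compound 2. Nothing available here explains these numbers.

As far as these compounds go, it remains open whether benzyl on sulfur would give a number like that of compound 3, which would test whether selenium still matters once the phenyl is present. Also open, from the compounds shown here alone, is how a longer chain, an amine or a carboxylic acid on the chain bound to selenium would read in this assay.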